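Bromo in Place of Hydroxy: An Expected Weaker Inhibitor

The source may report more compounds than this note shows. Statements on the series, on what has been measured and on what is new or still open speak of the compounds shown alone.

Compound 1 `COc1ccc(C(=O)ON=C2CC(c3ccc(O)c(OC)c3)N(C)C(c3ccc(O)c(OC)c3)C2)cc1` gives 33000 nM in a functional assay, read by spectrophotometry, with a stated time of 30 min; a lower number here means a stronger inhibitor, a higher number a weaker inhibitor.
Compound 2 `COc1cc(C2CC(=NOC(=O)c3ccc(Cl)cc3)CC(c3ccc(O)c(OC)c3)N2C)ccc1O` gives 112000 nM in this assay.
Compound 3 `COc1cc(C2CC(=NOC(=O)c3ccc(O)cc3)CC(c3ccc(O)c(OC)c3)N2C)ccc1O` gives 15100 nM in this assay.

Of these three numbers, compound 3 has the lowest and is therefore the strongest inhibitor of the set; compound 1 stands nearest to it and compound 2 furthest. Compound 4 `COc1cc(C2CC(=NOC(=O)c3ccc(Br)cc3)CC(c3ccc(O)c(OC)c3)N2C)ccc1O` differs from compound 3 by one change: bromo in place of hydroxy on an aromatic carbon.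

Among the compounds with values here, two measured steps bear on this change. Putting hydroxy in place of chloro at the same position gave a 7.4-fold lower number from compound 2 to compound 3 (0.87 log units; beyond the scatter), and putting chloro in place of methoxy gave a 3.4-fold higher number from compound 1 to compound 2 (0.53 log units; beyond the scatter). Within the data shown here, no compound with bromo has been measured. Bromo, like chloro, brings no hydrogen-bond donor and no hydrogen-bond acceptor, so the step from compound 3 to compound 4 is expected to resemble the reverse of the step from compound 2 to compound 3 in this assay: a modest rise in the number, well beyond the scatter, that is, a 6.6-fold higher number from compound 3 to compound 4 (0.82 log units; beyond the scatter). For compound 4 the estimate in this assay is 100000 nM, with a likely range from 35000 nM to 300000 nM.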

Compound 4, half-maximal inhibitory concentration: 108000 nM
Estimate against measurement, compound 4: 1.1-fold (0.03 log units) below, and the stated range covers the measured number.
By their numbers in this assay, from the lowest: compound 3; then compound 1; then compounds 4 and 2 (each within the scatter of the next).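

In this assay, this position does not separate the two halogens: the printed step is a 1.0-fold lower number from compound 2 to compound 4 (0.02 log units; within the scatter), so bromo and chloro read alike here. Replacing hydroxy with bromo gives a 7.2-fold higher number from compound 3 to compound 4 (0.85 log units; beyond the scatter), and this loss closely mirrors the gain in the earlier step of a 7.4-fold lower number from compound 2 to compound 3 (0.87 log units; beyond the scatter), so the hydroxy result now stands apart from two halogens rather than from chloro alone. Methoxy sits in between, with bromo in its place giving a 3.3-fold higher number from compound 1 to compound 4 (0.51 log units; beyond the scatter), so the four groups at this position fall into the order hydroxy, methoxy, then the two halogens together.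

Nothing available explains why the halogens match or why hydroxy gives the lowest number. Going by these compounds, whether an amine or a carboxylic acid at this position would reach or pass hydroxy, and whether fluoro would join chloro and bromo, remains open.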